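A few compounds are considered here, and "the series" means these few. Any claim that something is new, unique, unknown or untested is made for them only; others in the source may bear on it.

Measured in a functional assay on K562 cells (Homo sapiens) for antiproliferative activity, read by MTT assay, with a stated time of 6 days; a lower number here means a stronger inhibitor, a higher number a weaker inhibitor
compound 1 `O=C1C=C[C@@H](OCc2ccccc2)[C@@H]([C@@H](COC(=O)/C=C/c2ccccc2)OCc2ccccc2)O1` gives 1590 nM
compound 2 `CC(=O)O[C@@H]1C=CC(=O)O[C@@H]1[C@@H](COC(=O)/C=C/c1ccc(F)cc1)OC(C)=O` gives 3460 nM

Compound 1 holds the lower of the two numbers, and the gap to compound 2 lies beyond the scatter. Compound 3 `O=C1C=C[C@@H](OCc2ccccc2)[C@@H]([C@@H](CO)OCc2ccccc2)O1` is the unmeasured partner of compound 1, and the change is hydrogen in place of (2-phenylethenyl)carbonyl on an oxygen on a saturated carbon in the series. In words, hydrogen stands in place of (2-phenylethenyl)carbonyl on an oxygen on a saturated carbon, leaving hydroxymethyl. Among the measured compounds shown here, no measured pair shows this change, and both measured compounds still carry an ester on that oxygen, so the size of the step is poorly defined. A moderate move towards a higher number, meaning a weaker inhibitor, is expected from compound 1 at 1590 nM in this assay for now. The expected change is a 2.5-fold higher number from compound 1 to compound 3 (0.40 log units; beyond the scatter) as a working estimate. The estimated value for compound 3 is 4000 nM with an expected range from 1200 nM to 14000 nM in these notes.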

Compound 3, half-maximal inhibitory concentration: 1420 nM
Compound 3: middle estimate off by 2.8-fold (0.45 log units), on the high side; low and high end bracket the measured number.
By their numbers in this assay, from the lowest: compounds 3 and 1 (each within the scatter of the next); then compound 2.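

In this assay, hydrogen in place of (2-phenylethenyl)carbonyl on an oxygen on a saturated carbon gives a 1.1-fold lower number from compound 1 to compound 3 (0.05 log units; within the scatter), so compound 1 and compound 3 cannot be told apart. For this pair, the whole ester group, with its six-membered aromatic ring of carbon only, can be replaced by the free hydroxymethyl without a readable shift in the number. No supporting measurement bears on this result.

Compound 2 differs from compound 1 in more than one place, so its number says nothing specific about this oxygen. Open, as far as these compounds go, is whether a small group such as a methyl ether, or an amine or carboxylic acid in place of the hydroxy of hydroxymethyl, would also leave the number within the scatter.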